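Isopropyl to Methylpyrazole on the Core: Stability Outlook

A few compounds are considered here, and "the series" means these few. Any claim that something is new, unique, unknown or untested is made for them only; others in the source may bear on it.

Three compounds were measured in an ADME assay on microsomes from liver (Rattus norvegicus) for metabolic stability, with a stated time of 60 min, tested at 1 uM; a lower number here means that less of the compound is left, a higher number that more of the compound is left:

Compound 1 `COc1cc(-c2cnn3cc(OC)c(C(C)C)nc23)ccn1`: 14%
Compound 2 `COc1cc(-c2cnn3cc(OC)c(C4CCCC4)nc23)ccn1`: 7%
Compound 3 `COc1cc(-c2cnn3cc(OC)c(C4CCOC4)nc23)ccn1`: 34%

Compound 1 stands second highest of the three. Its nearest neighbour is compound 2, with a number 7 percentage points lower from compound 1 to compound 2 (within the scatter); its furthest is compound 3, with a number 20 percentage points higher from compound 1 to compound 3 (beyond the scatter).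

Compound 4 `COc1cc(-c2cnn3cc(OC)c(-c4cnn(C)c4)nc23)ccn1` differs from compound 1 by 1-methyl-1H-pyrazol-4-yl in place of isopropyl on an aromatic carbon.

Among the compounds with values here, the steps that bear on this are those into compound 3, where a ring carrying hetero atoms entered in place of an alkyl group: a number 20 percentage points higher from compound 1 to compound 3 (beyond the scatter) and a number 27 percentage points higher from compound 2 to compound 3 (beyond the scatter), both modest rises. The alkyl-to-alkyl step a number 7 percentage points lower from compound 1 to compound 2 (within the scatter) was within the scatter. Compound 4 is therefore expected to show a modest rise, a number 24 percentage points higher from compound 1 to compound 4 (beyond the scatter). Compound 4 is estimated at 38%, within 15% to 65%.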

Compound 4, percent of the compound remaining: 56%
The estimate for compound 4 lay 18 percentage points below the measured number; the range from low to high includes it.
By their numbers in this assay, from the lowest: compounds 2 and 1 (each within the scatter of the next); then compound 3; then compound 4.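

In this assay, this aromatic carbon next to the ring nitrogen accepts an aromatic ring, and 1-methyl-1H-pyrazol-4-yl gives the highest number of the series, going further than the saturated oxolan-3-yl (a number 22 percentage points higher from compound 3 to compound 4 (beyond the scatter)). Its gain over the alkyl groups is large, both against isopropyl (a number 42 percentage points higher from compound 1 to compound 4 (beyond the scatter)) and against cyclopentyl (a number 49 percentage points higher from compound 2 to compound 4 (beyond the scatter)). The compounds shown leave open whether the methyl on the pyrazole contributes, and whether a pyridine ring or a piperidine at this carbon would match it. Nothing shown here gives a reason for these rises.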